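This account rests on a few compounds, and the source may have more. Where it says the series, first, only, none or still open, it means among the compounds named here.

Measured so far in an ADME assay on Huh-7 cells (Homo sapiens) for cytotoxicity; on this read-out higher numbers stand for lower toxicity in this test and lower numbers for higher toxicity in this test:
compound 1 `CC(C)CCc1cc(C2=NS(=O)(=O)c3ccccc3N2)c(O)c2ccccc12` gives 37000 nM;
compound 2 `COc1c(C2=NS(=O)(=O)c3ccccc3N2)cc(CCC(C)C)c2ccccc12` gives 13000 nM;
compound 3 `COc1c(C2=NS(=O)(=O)c3cc(NS(C)(=O)=O)ccc3N2)c(OC)c2ccccc2c1CCC(C)C` gives 40000 nM.

Going by the values given here, the one counted step is hydrogen in place of methyl on an oxygen on an aromatic ring, which gave a 2.8-fold higher number from compound 2 to compound 1 (0.45 log units; beyond the scatter). Compound 3 and compound 1 sit within the usual scatter of each other; compound 3 and compound 2 lie further apart, beyond the scatter. The difference between the core of compound 3 and the core of compound 2 is not broken down here.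

Compound 4 `COc1c(C2=NS(=O)(=O)c3cc(NS(C)(=O)=O)ccc3N2)c(O)c(CCC(C)C)c2ccccc12` is not yet measured. Among the compounds with values here, it differs from compound 3 by hydrogen in place of methyl on an oxygen on an aromatic ring, the same change as the one from compound 2 to compound 1, with the same surroundings. In this assay a similar step is expected for compound 4, a 2.1-fold higher number from compound 3 to compound 4 (0.33 log units; beyond the scatter), because the earlier instance gave a 2.8-fold higher number from compound 2 to compound 1 (0.45 log units; beyond the scatter). Compound 4 is therefore estimated at 85000 nM, between 35000 nM and 200000 nM.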

Compound 4, half-maximal cytotoxic concentration: 110000 nM
The estimate for compound 4 lay 1.3-fold (0.11 log units) below the measured number; low and high end bracket the measured number.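

In this assay, methoxy to hydroxy on the core of compound 3 gives a 2.8-fold higher number from compound 3 to compound 4 (0.44 log units; beyond the scatter), and this matches the earlier step on the other core: the same change on two cores in this assay, a 2.8-fold higher number (0.45 log units; beyond the scatter) from compound 2 to compound 1 and a 2.8-fold higher number (0.44 log units; beyond the scatter) from compound 3 to compound 4, 1.0-fold (0.01 log units) apart, within the scatter of two such steps

In this series the change therefore carries over between these two cores, in direction and in size, with hydroxy giving the higher number and so the lower toxicity in this test. Two instances do not show that it holds on any further core, and they do not say what lies behind the step.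

Open, going by these compounds, is how an ethoxy group, an amine or a carboxylic acid in place of the hydroxy would compare. Also open, on these data alone, is whether a longer chain in place of the methyl on that oxygen would follow the methoxy compounds.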